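This account rests on a few compounds, and the source may have more. Where it says the series, first, only, none or still open, it means among the compounds named here.

Three compounds have so far been measured in an in vivo ADME assay on the whole organism for pharmacokinetics, with Canis familiaris (Canis lupus familiaris) as the target, at a dose of 0.6 mg/kg; on this read-out higher numbers stand for fast clearance and lower numbers for slow clearance:

Compound 1 `CC[C@H](C)[C@@H]1C(=O)N[C@H](C2Cc3ccccc3C2)C(=O)N1[C@@H](C(=O)N(C)C)c1ccc(C)[n+]([O-])c1` gives 14 mL/min/kg.
Compound 2 `CC[C@H](C)[C@@H]1C(=O)N[C@H](C2Cc3ccccc3C2)C(=O)N1[C@@H](C(=O)N(C)C)c1ccc(C)nc1C` gives 14 mL/min/kg.
Compound 3 `CC[C@@H](C)[C@@H]1C(=O)N[C@H](C2Cc3ccccc3C2)C(=O)N1[C@@H](C(=O)N1CCOCC1)c1ccc(C)nc1` gives 20 mL/min/kg.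

Compound 2 sits level with compound 1, and compound 3 lies close to both, so the three numbers fall within the usual scatter of one another and no ranking among them can be read.

Compound 4 `CC[C@H](C)[C@@H]1C(=O)N[C@H](C2Cc3ccccc3C2)C(=O)N1[C@@H](C(=O)N(C)C)c1cnc(C)cc1C` has not yet been measured. It keeps every atom of compound 2 and only rearranges the aromatic ring on the saturated chain carbon bound to an amide-type nitrogen in a ring and a carbonyl carbon: 4,6-dimethylpyridin-3-yl in place of 2,6-dimethylpyridin-3-yl on a saturated chain carbon bound to an amide-type nitrogen in a ring and a carbonyl carbon

Within the data shown here, only one measured step touches that same position. There, no change at the digits printed from compound 1 to compound 2 (within the scatter), so exchanging one six-membered aromatic ring with one hetero atom for another at this spot left the read-out unmoved. Among the measured compounds shown here, no measured step tests the exchange of 2,6-dimethylpyridin-3-yl for 4,6-dimethylpyridin-3-yl itself. With the atoms unchanged and the nearest comparison flat, the expected step in this assay is none beyond the scatter, no change at the digits printed from compound 2 to compound 4 (within the scatter). Compound 4 is therefore estimated at 14 mL/min/kg, with a range from 8 mL/min/kg to 25 mL/min/kg.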

Compound 4, clearance: 12 mL/min/kg
Estimate against measurement, compound 4: 1.2-fold (0.07 log units) above, within the range that was stated.
By their numbers in this assay, from the lowest: compounds 4, 1, 2 and 3 (each within the scatter of the next).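

In this assay, among these compounds, putting 4,6-dimethylpyridin-3-yl in place of 2,6-dimethylpyridin-3-yl gives a 1.2-fold lower number from compound 2 to compound 4 (0.07 log units; within the scatter), which is the first direct test at this place of the same atoms joined differently on the ring. Comparing the new ring with the ring of compound 1 gives a 1.2-fold lower number from compound 1 to compound 4 (0.07 log units; within the scatter), so the three aromatic rings tried on this saturated chain carbon, in compounds 1, 2 and 4, all lie within the scatter of one another, and dog clearance does not tell them apart. Nothing available offers a reason for this flat result.

Going by these compounds, all three of these rings are six-membered aromatic rings with one hetero atom and carry methyl groups, so it remains open whether a very different group at this place, such as a carboxylic acid on the ring or a saturated piperidine in place of the ring, would move the clearance. On these data alone, compound 3 differs from the others in more than one place, so what its morpholine amide alone does to clearance also remains open.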